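A few compounds are considered here, and "the series" means these few. Any claim that something is new, unique, unknown or untested is made for them only; others in the source may bear on it.

Measured in a functional assay on HeLa cells (Homo sapiens) for cytotoxicity; a lower number here means a stronger inhibitor, a higher number a weaker inhibitor:

Compound 1 `CCCCCCCCSC1=CC(=O)C(C[C@]2(C)[C@@H](C)CC[C@]3(C)C(C)=CCC[C@@H]23)=CC1=O`: > 100000 nM (a limit of the assay, not a number)
Compound 2 `CC1=CCC[C@H]2[C@](C)(CC3=CC(=O)C=CC3=O)[C@@H](C)CC[C@]12C`: 26800 nM
Compound 3 `CC1CCC[C@H]2[C@](C)(CC3=CC(=O)C(Cl)=CC3=O)[C@@H](C)CC[C@]12C`: 34100 nM

Compound 1 has no exact number on this scale, only a limit: the limit of > 100000 nM in this assay, at which 1 of the 3 values shown sits.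

Compound 4 `CCCSC1=CC(=O)C(C[C@]2(C)[C@@H](C)CC[C@]3(C)C(C)=CCC[C@@H]23)=CC1=O` keeps the sulfur of compound 1 but carries a shorter chain. The change is hydrogen in place of pentyl on a saturated chain carbon, three bonds along the chain from a sulfur, which amounts to octyl to propyl.

For the measured compounds named here, only one measured step bears on this change: an at least 3.7-fold lower number from compound 1 to compound 2 (0.57 log units; beyond the scatter). That step swaps the whole octylsulfanyl group for hydrogen, whereas compound 4 loses only the outer part of the chain. A shift in the same direction is therefore a reasonable expectation, with compound 4 landing in the region of compound 2 at 26800 nM. Going by the values given here, no measured compound has a chain of intermediate length, so this remains uncertain, and compound 4 could still reach the limit.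

The expected step is an at least 2.5-fold lower number from compound 1 to compound 4 (0.39 log units; beyond the scatter).

In this assay the estimate for compound 4 is 40000 nM, with an expected range from 12000 nM to 100000 nM.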

Compound 4, half-maximal inhibitory concentration: 97000 nM
Estimate against measurement, compound 4: 2.4-fold (0.38 log units) below; low and high end bracket the measured number.
By their numbers in this assay, from the lowest: compounds 2 and 3 (each within the scatter of the next); then compound 4. At a limit, above all of these: compound 1.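

Putting propylsulfanyl in place of hydrogen on a double-bonded ring carbon gives a 3.6-fold higher number from compound 2 to compound 4 (0.56 log units; beyond the scatter) in this assay, so this position now has an exact measured penalty for a sulfur-linked chain, where the earlier comparison offered only a floor. Even a chain as short as propyl does not keep the number of the unsubstituted compound 2, which means the octyl chain is not needed for the loss to appear. Cutting octyl to propyl gives an at least 1.0-fold lower number from compound 1 to compound 4 (0.01 log units; that floor lies within the scatter), and the size of this change cannot be read, because compound 1 has no exact number and only a limit of the assay: the limit of > 100000 nM in this assay, at which 1 of the 4 values shown sits.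

Whether chain length matters at all on the sulfur therefore stays unsettled, and a butyl or hexyl chain would be needed to trace any trend between compound 4 and compound 1. From the compounds shown here alone, it also remains open whether a methyl chain on the sulfur, or a propyl chain ending in an amine or a carboxylic acid, would bring the number back toward that of compound 2, which stands at 26800 nM.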